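The source may hold more compounds than are shown below. What is called first, only, known or untested is meant among the compounds shown, and "the series" means these compounds.

Working notes on the benzylsulfanyl sulfonylamidine series.

Of the compounds shown here, two have been measured in an ADME assay on microsomes from liver (Homo sapiens) for metabolic stability, read by LC-MS, using NADPH, tested at 5 uM; a lower number here means that the compound disappears faster, a higher number that the compound lasts longer. Compound 1 `Cc1ccc(CSc2cc(Cl)c(C)cc2S(=O)(=O)/N=C(\N)n2nc(C)cc2-c2ccccc2)cc1` gives 0.176 h. Compound 2 `Cc1cc(S(=O)(=O)/N=C(\N)n2nccc2-c2ccccc2)c(SCc2ccccc2C)cc1Cl` gives 0.0802 h. On these two numbers compound 2 stands lowest; compound 1 sits a step above it that lies beyond the scatter. Compound 1 and compound 2 differ in more than one place, so their two values are simply recorded side by side.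

Compound 3 `Cc1ccc(CSc2cc(Cl)c(C)cc2S(=O)(=O)/N=C(\N)n2nccc2-c2ccccc2)cc1` has not yet been measured in this assay. It differs from compound 2 in one place: 4-methylphenyl in place of 2-methylphenyl on a saturated chain carbon bound to a sulfur. Going by the values given here, no measured pair isolates this change, so the direction is read only from where compound 2 stands against compound 1. The expected step from compound 2 to compound 3 is a 1.5-fold higher number from compound 2 to compound 3 (0.18 log units; within the scatter), upward but within the scatter. Compound 3 is therefore estimated at 0.12 h, with a range from 0.06 h to 0.25 h.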

Compound 3, half-life: 0.13 h
Beside the measured number, compound 3's estimate is 1.1-fold (0.03 log units) below it; the range from low to high includes it.
By their numbers in this assay, from the lowest: compounds 2, 3 and 1 (each within the scatter of the next, the first and the last beyond it).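

In this assay, going by these compounds alone, 4-methylphenyl in place of 2-methylphenyl on a saturated chain carbon bound to a sulfur gives a 1.6-fold higher number from compound 2 to compound 3 (0.21 log units; within the scatter), the first isolated reading of this position. The other isolated change, hydrogen in place of methyl on an aromatic carbon, gives a 1.4-fold lower number from compound 1 to compound 3 (0.13 log units; within the scatter), so the methyl on that carbon can now be read apart from the change on the benzyl group. Neither single change takes the half-life beyond the scatter, so on these compounds neither the place of the methyl on the phenyl ring nor the loss of the aromatic-carbon methyl is a clear lever.

From the compounds shown here alone, whether an amine or a carboxylic acid on that phenyl ring, or a longer chain on the sulfur, would move the half-life beyond the scatter remains open. The data shown give no basis for explaining either step.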